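A Small Change at an Aromatic Nitrogen, Carried Over

The source may hold more compounds than are shown below. What is called first, only, known or untested is meant among the compounds shown, and "the series" means these compounds.

In an ADME assay on MDBK cells (Bos taurus) for cytotoxicity, read by MTT assay, with a stated time of 96 h (a higher number here means that more compound is tolerated, a lower number that less compound is tolerated), compound 1 `CCN(CC)CC(=O)Nc1ccc(-c2nc3cc(C(F)(F)F)ccc3n2C)cc1` gives 57000 nM. Compound 2 `CCN(CC)CC(=O)Nc1ccc(-c2nc3cc(C(F)(F)F)ccc3[nH]2)cc1` differs from it only by hydrogen in place of methyl on an aromatic nitrogen, and gives 13000 nM, a step of a 4.4-fold lower number from compound 1 to compound 2 (0.64 log units; beyond the scatter). Compound 3 `Cn1c(-c2ccc(NC(=O)CN3CCN(c4ccccc4)CC3)cc2)nc2cc(C(F)(F)F)ccc21` carries a different side chain, (4-phenylpiperazin-1-yl in place of diethylamino on a saturated chain carbon bound to a carbonyl carbon), and gives 1400 nM, a step of a 41-fold lower number from compound 1 to compound 3 (1.61 log units; beyond the scatter). Compound 4 `O=C(CN1CCN(c2ccccc2)CC1)Nc1ccc(-c2nc3cc(C(F)(F)F)ccc3[nH]2)cc1` has not yet been measured in this assay; it differs from compound 3 by hydrogen in place of methyl on an aromatic nitrogen, the same change that separates compound 1 from compound 2, at the same place. Within the data shown here, the step from compound 3 to compound 4 is expected to be a 3.5-fold lower number from compound 3 to compound 4 (0.54 log units; beyond the scatter), close to the earlier one, because a 4.4-fold lower number from compound 1 to compound 2 (0.64 log units; beyond the scatter) is the only measured example of this change and rests on a single pair. Compound 4 is therefore estimated at 400 nM, between 150 nM and 1200 nM.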

Compound 4, half-maximal cytotoxic concentration: 32000 nM
For compound 4 the middle estimate is 80-fold (1.90 log units) below the measured one; the measured number lies above the stated range.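

In this assay, hydrogen in place of methyl on the aromatic nitrogen gives a 23-fold higher number from compound 3 to compound 4 (1.36 log units; beyond the scatter) and so runs the opposite way to the earlier step on the diethylamino side chain. The change therefore did not carry over from one core to the other, in either direction or size: the same change on two cores in this assay, a 4.4-fold lower number (0.64 log units; beyond the scatter) from compound 1 to compound 2 and a 23-fold higher number (1.36 log units; beyond the scatter) from compound 3 to compound 4, 100-fold (2.00 log units) apart, beyond the scatter of two such steps. Among these compounds, this shows that a step measured on one core cannot be assumed on another, but with only two pairs it does not show why they differ or which direction is more usual.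

The compounds shown leave open how the change behaves with other side chains, such as a morpholine or a piperidine. They also leave open what a longer chain, such as ethyl, would do on the aromatic nitrogen.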